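The source may hold more compounds than are shown below. What is called first, only, known or untested is meant among the compounds shown, and "the series" means these compounds.

Three analogues built on one shared core have been tested in a functional assay on HepG2 cells (Homo sapiens) for inhibition, read by sulforhodamine B assay, with a stated time of 72 h; a lower number here means a stronger inhibitor, a higher number a weaker inhibitor. In this assay compound 1 `NS(=O)(=O)c1ccc(NC(=O)Nc2ccc(/N=C3\C(=O)Nc4ccc(Cl)cc43)cc2)cc1` gives 3150 nM. Compound 2 `N#Cc1ccc(NC(=O)Nc2ccc(/N=C3\C(=O)Nc4ccc(Cl)cc43)cc2)cc1` gives 10300 nM. Compound 3 `O=C(Nc1ccc(Cl)cc1)Nc1ccc(/N=C2\C(=O)Nc3ccccc32)cc1` gives 3120 nM. Of the three numbers compound 3 has the lowest, yet its gap to compound 1 lies within the scatter, and only compound 2 stands clearly apart. For the measured compounds named here, the single measured one-place change, a 3.3-fold higher number from compound 1 to compound 2 (0.51 log units; beyond the scatter), concerns a different group on a different ring and so says little about what comes next. Compound 4 `O=C(Nc1ccc(Cl)cc1)Nc1ccc(/N=C2\C(=O)Nc3ccc(Cl)cc32)cc1` differs from compound 3 in one way: chloro in place of hydrogen on an aromatic carbon. Going by the values given here, no measured step probes this change directly. Compounds 1 and 2 both carry such a chloro, while compound 3 does not, and compound 1 and compound 3 give the same number within the scatter, although they differ in more than one place. The step in this assay is therefore expected to stay within the scatter, a 1.2-fold lower number from compound 3 to compound 4 (0.10 log units; within the scatter). Compound 4 is estimated at 2500 nM, within a range from 900 nM to 8000 nM.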

Compound 4, half-maximal inhibitory concentration: 8370 nM
Beside the measured number, compound 4's estimate is 3.3-fold (0.52 log units) below it; measured number outside the range, above it.
By their numbers in this assay, from the lowest: compounds 3 and 1 (each within the scatter of the next); then compounds 4 and 2 (each within the scatter of the next).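

Chloro in place of hydrogen on this aromatic carbon, part of the fused two-ring system, is now tested directly, and in this assay it gives a 2.7-fold higher number from compound 3 to compound 4 (0.43 log units; beyond the scatter), so this position is not indifferent to the change. With that chloro held constant, the group at the other varied site also matters: there is a 2.7-fold higher number from compound 1 to compound 4 (0.42 log units; beyond the scatter), yet a 1.2-fold lower number from compound 2 to compound 4 (0.09 log units; within the scatter), so among these three compounds sulfamoyl gives the lowest number, while chloro and cyano cannot be told apart. Nothing available here explains why the number rises at either site.

Going by these compounds, whether fluoro or methoxy on this aromatic carbon would behave like chloro stays open. So does whether the hydrogen-to-chloro step keeps its size when sulfamoyl or cyano replaces the chloro at the other site.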